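This account rests on a few compounds, and the source may have more. Where it says the series, first, only, none or still open, it means among the compounds named here.

Working notes on the series. In a functional assay on the whole organism (Gastrocnemius, strain Sprague-Dawley) for inhibition, with Rattus norvegicus as the target (a higher number here means that more compound is needed for the effect, a lower number that less compound is needed), compound 1 (`O=C1NC(=O)N(/N=C/c2ccc(-c3ccc(Cl)cc3)o2)C1O`) gives 0.016 umol/kg and sets the lowest number. Compound 3 (`Nc1ccc(-c2ccc(/C=N/N3C(=O)NC(=O)C3O)o2)cc1`) gives 0.039 umol/kg and so holds the higher of the two exact numbers. Compound 2 (`CC(=O)Nc1ccc(-c2ccc(/C=N/N3C(=O)NC(=O)C3O)o2)cc1`) reaches only a limit (> 0.107 umol/kg).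

Compound 4 (`O=C1NC(=O)N(/N=C/c2ccc(-c3ccc([N+](=O)[O-])cc3)o2)C1O`) changes compound 3 at one place, with nitro in place of amino on an aromatic carbon, para to a large group: nitro in place of amino on an aromatic carbon.

All measured steps concern this same place. The step of a 2.4-fold higher number from compound 1 to compound 3 (0.39 log units; beyond the scatter) is modest and beyond the scatter. The steps of an at least 6.6-fold higher number from compound 1 to compound 2 (0.82 log units; beyond the scatter) and an at least 2.7-fold lower number from compound 2 to compound 3 (0.43 log units; beyond the scatter) both involve the acetamido group and rest on a limit. Among the compounds with values here, no measured step has nitro entering, so the size is a judgement from the modest step to compound 3 (0.039 umol/kg) and leans towards compound 1.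

A small move to a lower number is expected, possibly within the scatter. The estimated step is a 1.6-fold lower number from compound 3 to compound 4 (0.19 log units; within the scatter) in this assay as a whole. For compound 4 the estimated value is 0.025 umol/kg with an expected range from 0.008 umol/kg to 0.08 umol/kg.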

Compound 4, dose for half-maximal effect: 0.015 umol/kg
For compound 4 the middle estimate is 1.7-fold (0.22 log units) above the measured one, within the range that was stated.
By their numbers in this assay, from the lowest: compounds 4 and 1 (each within the scatter of the next); then compound 3. At a limit, above all of these: compound 2.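

In this assay, on this aromatic carbon para to a large group, nitro and chloro cannot be told apart, with a 1.1-fold lower number from compound 1 to compound 4 (0.03 log units; within the scatter). Amino is separated from nitro by a real gap, with a 2.6-fold lower number from compound 3 to compound 4 (0.41 log units; beyond the scatter), so a nitrogen-bearing group at this position does not in itself go with the higher number, as compounds 3 and 4 differ here while both carry one. Compound 2 reaches only a limit, and the step of an at least 7.1-fold lower number from compound 2 to compound 4 (0.85 log units; beyond the scatter) rests on that limit: the limit of > 0.107 umol/kg in this assay, at which 1 of the 4 values shown sits.

As far as these compounds go, it remains open whether a nitrile, a trifluoromethyl or a carboxylic acid on this carbon would sit with compounds 1 and 4 or with compound 3. The compounds shown also leave open whether chloro and nitro would still be indistinguishable at another place on the six-membered ring.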